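Carbamoyl to Amino(carboxy)methyl on a Shared Core

The source may report more compounds than this note shows. Statements on the series, on what has been measured and on what is new or still open speak of the compounds shown alone.

For the measured compounds named here, compound 2 `COc1cc2c(cc1O)CCC(C)(CC(N)=O)O2` holds the highest of the two numbers measured so far in an ADME assay on SH-SY5Y cells (Homo sapiens) for cytotoxicity, read by MTT assay, with a stated time of 24 h, tested at 50 uM (a lower number here means a stronger effect, a higher number a weaker effect of the compound at the concentration tested), giving 99.2%. Going by the values given here, its nearest companion, compound 1 `COc1cc2c(cc1O)CCC(C)(CC(=O)N[C@H](C(=O)O)C(C)C)O2`, gives 79.3%, and the single measured step, a number 19.9 percentage points higher from compound 1 to compound 2 (beyond the scatter), runs from a carboxy-bearing amide to the plain amide. Compound 3 `COc1cc2c(cc1O)CCC(C)(CC(N)C(=O)O)O2` differs from compound 2 as follows: amino(carboxy)methyl in place of carbamoyl on a saturated chain carbon bound to a saturated ring carbon. Compound 1, which also carries a carboxy group, sits lower than compound 2, so a move back toward that value is expected. The step of a number 11.2 percentage points lower from compound 2 to compound 3 (beyond the scatter) is estimated as a modest fall. Compound 3 is therefore expected to give 88%, within 72% to 100%.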

Compound 3, a percentage reported as activity, at one concentration (the size of the read-out at that concentration, not a potency): 85.7%
Compound 3: the middle estimate sits 2.3 percentage points above what was measured; the range from low to high includes it.
By their numbers in this assay, from the lowest: compounds 1 and 3 (each within the scatter of the next); then compound 2.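

For the compounds shown here, until now, the only step in this assay had changed the substituent on the amide-type nitrogen; this one replaces the carbamoyl group itself. Amino(carboxy)methyl in place of carbamoyl on a saturated chain carbon bound to a saturated ring carbon gives a number 13.5 percentage points lower from compound 2 to compound 3 (beyond the scatter), so a change at this place also moves the read-out. Nothing available explains this step. The compounds shown leave open whether a plain aminomethyl group or a carboxylic acid alone at this place would give a similar number, and what a longer chain would do.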